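The source may hold more compounds than are shown below. What is called first, only, known or untested is meant among the compounds shown, and "the series" means these compounds.

Compound 1 `CC(O)(COc1ccc(C#N)cc1)C(=O)Nc1ccc(S(F)(F)(F)(F)F)cc1` and compound 3 `CC(O)(COc1ccc(C#N)cc1)C(=O)Nc1cccc(S(F)(F)(F)(F)F)c1` are made of the same atoms joined differently; the difference between the two cores is not broken down here. In a functional assay on LNCaP cells (Homo sapiens) for antiproliferative activity, read by propidium iodide staining, with a stated time of 96 h (a higher number here means a weaker inhibitor, a lower number a stronger inhibitor), compound 1 gives 100000 nM. In this assay compound 3 gives 30000 nM, the lowest of the three measured numbers, and its gap to each of the other two lies beyond the usual scatter. Compound 2 `CC(O)(COc1ccc(C#N)c(F)c1)C(=O)Nc1ccc(S(F)(F)(F)(F)F)cc1` is obtained from compound 1 by fluoro in place of hydrogen on an aromatic carbon. In this assay compound 2 gives 100000 nM, so that no change at the digits printed from compound 1 to compound 2 (within the scatter).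

Compound 4 `CC(O)(COc1ccc(C#N)c(F)c1)C(=O)Nc1cccc(S(F)(F)(F)(F)F)c1` stands to compound 3 as compound 2 stands to compound 1: it carries fluoro in place of hydrogen on an aromatic carbon. The surroundings of the new fluorine are described in the same words for both pairs, so this is the same change, seen only once so far among measured compounds. The expectation for compound 4 therefore rests on that single pair and on the starting point. Because compound 3 gives 30000 nM and the step of no change at the digits printed from compound 1 to compound 2 (within the scatter) shows no movement, compound 4 is expected to give about 30000 nM in this assay. The expected step is no change at the digits printed from compound 3 to compound 4 (within the scatter), beside the earlier one, which was within the scatter. For compound 4 the estimate is expected to span from 10000 nM to 90000 nM.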

Compound 4, half-maximal inhibitory concentration: 83700 nM
Estimate against measurement, compound 4: 2.8-fold (0.45 log units) below; measured number inside the range.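

In this assay, the swap of hydrogen for fluoro does not carry over from one core to the other with the same size, so a step read on one core is a poor guide to the same step on the other: the same change on two cores in this assay, no change at the digits printed (within the scatter) from compound 1 to compound 2 and a 2.8-fold higher number (0.45 log units; beyond the scatter) from compound 3 to compound 4, 2.8-fold (0.45 log units) apart, beyond the scatter of two such steps

The new pair gives a 2.8-fold higher number from compound 3 to compound 4 (0.45 log units; beyond the scatter), a modest step toward a weaker inhibitor, which the pair on the core of compound 1 did not show. Two pairs show only that the outcome of this change can depend on the core; they give no rule for a further core, and they do not tell why the two cores part ways.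

The compounds shown leave open whether the loss on the core of compound 3 belongs to fluoro in particular or would also come with another small group on the same aromatic carbon, such as chloro, methyl or methoxy. They also leave open how an amine or a carboxylic acid would read at that place, on either core, and so whether any group there could move these numbers toward a stronger inhibitor.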